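Chlorophenyl substitution pattern on the shared core

A few compounds are considered here, and "the series" means these few. Any claim that something is new, unique, unknown or untested is made for them only; others in the source may bear on it.

Among the measured compounds shown here, compound 1 `Cn1c(-c2cccc(Cl)c2)nc2c(NC3CCCC3)ncnc21` gives 514 nM in an assay on CHO cells for displacement of a labelled ligand from adenosine receptor A3 (Homo sapiens), read by scintillation counting, with a stated time of 3 h (a higher number here means a weaker inhibitor, a lower number a stronger inhibitor), the lowest of the three numbers measured so far. Compound 2 `COc1ccc(-c2nc3c(NC4CCCC4)ncnc3n2C)cc1` gives 1850 nM in this assay, and compound 3 `Cn1c(-c2cccnc2)nc2c(NC3CCCC3)ncnc21` gives 11000 nM. Replacing 3-chlorophenyl gave a 3.6-fold higher number from compound 1 to compound 2 (0.56 log units; beyond the scatter) and a 21-fold higher number from compound 1 to compound 3 (1.33 log units; beyond the scatter), and between those two aromatic groups the step was a 5.9-fold higher number from compound 2 to compound 3 (0.77 log units; beyond the scatter). Every change away from 3-chlorophenyl so far has weakened binding.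

Compound 4 `Cn1c(-c2ccc(Cl)cc2)nc2c(NC3CCCC3)ncnc21` differs from compound 1 in one place: 4-chlorophenyl in place of 3-chlorophenyl on an aromatic carbon. For the measured compounds named here, no measured step moves the chlorine alone while keeping the phenyl. The nearest comparison is a 3.6-fold higher number from compound 1 to compound 2 (0.56 log units; beyond the scatter), which changes both the substituent and its place at once, so it bears on compound 4 only loosely. A modest weakening, or no step beyond the scatter, is therefore expected; a large step like a 21-fold higher number from compound 1 to compound 3 (1.33 log units; beyond the scatter) is not, since the aromatic carbon ring itself is unchanged. For compound 4 the expected value in this assay is 800 nM, within 250 nM to 2600 nM, corresponding to an expected step of a 1.6-fold higher number from compound 1 to compound 4 (0.19 log units; within the scatter).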

Compound 4, inhibition constant: 1210 nM
Compound 4: the middle estimate sits 1.5-fold (0.18 log units) below what was measured; the measured number falls inside the stated range.
By their numbers in this assay, from the lowest: compound 1; then compounds 4 and 2 (each within the scatter of the next); then compound 3.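

Moving the chlorine with the phenyl kept gives a 2.4-fold higher number from compound 1 to compound 4 (0.37 log units; beyond the scatter) in this assay and thus shows that the place of the chlorine counts at this position, which no earlier step could separate from a change of substituent. Chloro and methoxy in the same place are not told apart by a 1.5-fold lower number from compound 2 to compound 4 (0.18 log units; within the scatter) so the earlier step from 3-chlorophenyl to 4-methoxyphenyl may owe more to the place of the substituent than to its identity. The change from pyridin-3-yl to 4-chlorophenyl gives a 9.1-fold lower number from compound 3 to compound 4 (0.96 log units; beyond the scatter) and so stays clear of the scatter even with the chlorine in the less favourable of its two places.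

Still open, going by these compounds, is whether 3-methoxyphenyl would match 3-chlorophenyl, and how an amine on the phenyl would compare. Nothing available here explains these steps.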